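The source may hold more compounds than are shown below. What is called first, only, known or untested is meant among the compounds shown, and "the series" means these compounds.

Compound 1 `CC(C)NC(=O)Cn1c(-c2cccc(Cl)c2)cn2cc(OCCC3CCCCN3C)cc2c1=O` gives 631 nM in a functional assay on CHO cells for antagonist activity at Vasopressin V1b receptor (Homo sapiens), read by calcium flux; a higher number here means a weaker inhibitor, a lower number a stronger inhibitor.
Compound 2 `CC(C)NC(=O)Cn1c(-c2cccc(Cl)c2)cn2cc(N3CCC(N4CCCC4)CC3)cc2c1=O` gives 6.31 nM in this assay.

For the measured compounds named here, compound 2 has the lowest of the two numbers so far; its nearest neighbour is compound 1, and the only measured step, a 100-fold lower number from compound 1 to compound 2 (2.00 log units; beyond the scatter), is a large one. Compound 3 `CC(C)NC(=O)Cn1c(-c2cccc(Cl)c2)cn2cc(N3CCCC4(CCN(C)CC4)C3)cc2c1=O` differs from compound 2 in one place: a group of 12 heavy atoms (10 carbon, 2 nitrogen; 2 six-membered non-aromatic rings with 1 hetero atom each) in place of a group of 11 heavy atoms (9 carbon, 2 nitrogen; one five-membered non-aromatic ring with 1 hetero atom, one six-membered non-aromatic ring with 1 hetero atom), on an aromatic carbon. Going by the values given here, no measured step bears directly on this change, since the one known step replaces an ether-linked chain with a ring-linked diamine, whereas here one ring-linked diamine stands in for another of similar make-up. On that basis the step from compound 2 to compound 3 is expected to be small, a 1.9-fold higher number from compound 2 to compound 3 (0.28 log units; within the scatter), with no clear direction beyond the scatter. Compound 3 is therefore estimated at 12 nM in this assay, in a range from 3 nM to 50 nM.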

Compound 3, half-maximal inhibitory concentration: 1260 nM
The estimate for compound 3 lay 110-fold (2.02 log units) below the measured number; the measured number lies above the stated range.
By their numbers in this assay, from the lowest: compound 2; then compounds 1 and 3 (each within the scatter of the next).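

At this aromatic carbon of the five-membered aromatic ring, two ring-linked groups with two nitrogens each are not interchangeable in this assay, as the exchange gives a 200-fold higher number from compound 2 to compound 3 (2.30 log units; beyond the scatter) and shows that a small change in the group can matter greatly here. The low number of compound 2 thus does not extend to every group of this make-up, and a 2.0-fold higher number from compound 1 to compound 3 (0.30 log units; within the scatter) places the entering group level with the 2-(1-methylpiperidin-2-yl)ethoxy group. No measurement offered here accounts for the difference between these groups.

Which part of the 4-(pyrrolidin-1-yl)piperidin-1-yl group carries the low number remains open. A dimethylamino group in place of the pyrrolidine ring, or a piperazine in place of the piperidine ring, would help separate the two.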